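Ethyl versus isopropyl on the piperazine of the shared core

The source may hold more compounds than are shown below. What is called first, only, known or untested is meant among the compounds shown, and "the series" means these compounds.

Measured so far:
compound 1, `C=CC(=O)Nc1cc(Nc2ncc(Cl)c(Nc3ccccc3S(=O)(=O)C(C)C)n2)c(OC)cc1N1CCN(C(C)C)CC1`, < 0.3 nM
compound 2, `C=CC(=O)Nc1cc(Nc2ncc(Cl)c(Nc3ccccc3C#N)n2)c(OC)cc1N1CCN(CC)CC1`, 110 nM

Within the data shown here, in a functional assay on NCI-H3122 cells (Homo sapiens) for inhibition, read by CellTiter-Glo, with a stated time of 72 h (a higher number here means a weaker inhibitor of growth, a lower number a stronger inhibitor of growth), compound 2 gives 110 nM and carries the only number among the two values shown. For compound 1 the reading of < 0.3 nM is a limit of the assay, not a number; the same holds for (the limit of < 0.3 nM in this assay, at which 1 of the 2 values shown sits). Compound 3, `C=CC(=O)Nc1cc(Nc2ncc(Cl)c(Nc3ccccc3C#N)n2)c(OC)cc1N1CCN(C(C)C)CC1`, has not yet been measured. It differs from compound 2 by methyl in place of hydrogen on a saturated chain carbon bound to an amine nitrogen in a ring and a saturated chain carbon. Among the measured compounds shown here, no pair of measured compounds is joined by this change alone, so no step of this kind is on record. A change of this size on the amine of the ring is expected to leave this assay essentially unchanged, with any shift no larger than the usual scatter, in no preferred direction; the step from compound 2 to compound 3 is estimated as a 1.2-fold lower number from compound 2 to compound 3 (0.09 log units; within the scatter). Compound 3 is therefore expected to give about 90 nM, within 30 nM to 270 nM.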

Compound 3, concentration for 50% growth inhibition: 110 nM
Compound 3: middle estimate off by 1.2-fold (0.09 log units), on the low side; the range from low to high includes it.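

In this assay the change from 4-ethylpiperazin-1-yl to 4-isopropylpiperazin-1-yl gives no change at the digits printed from compound 2 to compound 3 (within the scatter), so with cyano on the aromatic carbon this place accepts the added methyl. With 4-isopropylpiperazin-1-yl held constant, cyano in place of isopropylsulfonyl on an aromatic carbon gives an at least 360-fold higher number from compound 1 to compound 3 (2.56 log units; beyond the scatter), so this change alone accounts for a large step in the series. Compound 1 gives < 0.3 nM, a limit of the assay and not a number, so the full size of that step stays unknown: the limit of < 0.3 nM in this assay, at which 1 of the 3 values shown sits.

Open, as far as these compounds go, is whether ethyl and isopropyl on the piperazine also read alike when isopropylsulfonyl sits on the aromatic carbon. Also open, from the compounds shown here alone, is how a hydroxyethyl chain, a cyclohexyl group or a plain hydrogen on that piperazine nitrogen would read in this assay.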